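Working notes: from compound 1 to compound 4

The source may hold more compounds than are shown below. What is called first, only, known or untested is meant among the compounds shown, and "the series" means these compounds.

Measured in a physicochemical assay for lipophilicity; a higher number here means a more lipophilic compound, a lower number a more polar compound:
compound 1 `CC(=O)OCOC(=O)c1ccccc1OC(C)=O`: 1.42
compound 2 `COC(=O)c1ccccc1OC(C)=O`: 1.46
compound 3 `CC(=O)Oc1ccccc1C(=O)OC[S+](C)[O-]`: 0.141

Compound 1 sits within the scatter of compound 2, the step being a number 0.04 log units higher from compound 1 to compound 2 (within the scatter). Against the remaining compound the reading is a number 1.28 log units lower from compound 1 to compound 3 (beyond the scatter), so compound 1 stands well clear of compound 3.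

Next in line is compound 4 `CC(=O)Oc1ccccc1C(=O)OCC(=O)N(C)CCO`, with no number yet in this assay. The change is (2-hydroxyethyl)(methyl)carbamoyl in place of acetoxy on a saturated chain carbon bound to an oxygen next to a carbonyl group. All three measured steps fall at this same place, so all bear on it, though none involves the entering group. The step from compound 1 to compound 2 shows that losing acetoxy alone stays within the scatter. The steps to compound 3 are the only large ones, a number 1.28 log units lower from compound 1 to compound 3 (beyond the scatter) and a number 1.32 log units lower from compound 2 to compound 3 (beyond the scatter), and they serve as a loose guide to size. A downward step of similar size, beyond the scatter, is therefore expected, with real uncertainty attached. The expected step is a number 1.07 log units lower from compound 1 to compound 4 (beyond the scatter). For compound 4 the estimated value is 0.35, with an expected range from -0.15 to 0.85.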

Compound 4, partition coefficient: 0.06
Estimate against measurement, compound 4: 0.29 log units above; low and high end bracket the measured number.
By their numbers in this assay, from the lowest: compounds 4 and 3 (each within the scatter of the next); then compounds 1 and 2 (each within the scatter of the next).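

In this assay, (2-hydroxyethyl)(methyl)carbamoyl on the saturated chain carbon bound to an oxygen next to a carbonyl group gives a number 1.36 log units lower from compound 1 to compound 4 (beyond the scatter) and a number 1.40 log units lower from compound 2 to compound 4 (beyond the scatter), so a large downward step at this place is no longer seen with the sulfur-containing group of compound 3 alone. That group and the carbamoyl group differ in size and atom make-up, yet the two compounds cannot be told apart in this series, with a number 0.08 log units lower from compound 3 to compound 4 (within the scatter), and the measured compounds now fall into two pairs: compound 3 with compound 4, and compound 1 with compound 2. No measurement on hand accounts for the size of these steps.

As far as these compounds go, it remains open whether the step belongs to the carbamoyl unit as a whole or to its 2-hydroxyethyl chain, a question that a plain dimethylcarbamoyl group at the same place would help to separate. Also open, from the compounds shown here alone, is where a carboxylic acid, an amine or a longer hydroxyalkyl chain on this carbon would fall relative to these two pairs.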